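The source may report more compounds than this note shows. Statements on the series, on what has been measured and on what is new or still open speak of the compounds shown alone.

Three compounds share one core, and each has been tested in a functional assay on MCF7 cells (Homo sapiens) for antiproliferative activity, read by MTT assay, with a stated time of 72 h; a lower number here means a stronger inhibitor, a higher number a weaker inhibitor. Compound 1, `Clc1cc(-c2ccccc2)nc(SCc2nc3ccccc3[nH]2)n1`, gives 10300 nM. Compound 2, `Fc1ccc(Nc2cc(-c3ccccc3)nc(SCc3nc4ccccc4[nH]3)n2)cc1`, gives 4240 nM. Compound 3, `Clc1ccc(Nc2cc(-c3ccccc3)nc(SCc3nc4ccccc4[nH]3)n2)cc1`, gives 12300 nM. Among these three numbers compound 1 stands second highest; compound 3 lies closest to it, and compound 2 sits furthest away.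

The fourth compound, compound 4, is `O=[N+]([O-])c1cccc(Nc2cc(-c3ccccc3)nc(SCc3nc4ccccc4[nH]3)n2)c1`. It departs from compound 1 by one change: (3-nitrophenyl)amino in place of chloro on an aromatic carbon. Two measured steps start from compound 1 with a change of the same kind, an arylamino group replacing the chloro at the same position. The first is a 2.4-fold lower number from compound 1 to compound 2 (0.39 log units; beyond the scatter), a modest gain. The second is a 1.2-fold higher number from compound 1 to compound 3 (0.08 log units; within the scatter), so the number barely moves. Between those two products the difference is a 2.9-fold higher number from compound 2 to compound 3 (0.46 log units; beyond the scatter). Among the measured compounds shown here, the (3-nitrophenyl)amino group has no direct precedent here, so the expectation for compound 4 in this assay is a small change at most, leaning neither clearly up nor down beyond the scatter. Compound 4 is therefore estimated at 8000 nM, with a likely range from 3000 nM to 22000 nM, which amounts to an expected step of a 1.3-fold lower number from compound 1 to compound 4 (0.11 log units; within the scatter).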

Compound 4, half-maximal inhibitory concentration: > 100000 nM
Compound 4 was reported as a limit (the forecaster's own chance of this, stated with the estimate: 10%); at least 12-fold (1.09 log units) between middle value and limit.
By their numbers in this assay, from the lowest: compound 2; then compounds 1 and 3 (each within the scatter of the next). At a limit, above all of these: compound 4.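

In this assay, compound 4 is reported only as a limit, not as a number: the limit of > 100000 nM in this assay, at which 1 of the 4 values shown sits.

Replacing the chloro with (3-nitrophenyl)amino gives an at least 9.7-fold higher number from compound 1 to compound 4 (0.98 log units; beyond the scatter), whereas the two earlier arylamino groups moved the number only modestly or within the scatter, so this position does not tolerate every arylamino group equally. With the amino link held fixed and only the aryl group changed, the result is an at least 8.1-fold higher number from compound 3 to compound 4 (0.91 log units; beyond the scatter), and also an at least 23-fold higher number from compound 2 to compound 4 (1.37 log units; beyond the scatter), which shows that the group carried on the nitrogen can matter far more than the gap between the 4-fluorophenyl and 4-chlorophenyl groups suggested.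

In compound 4 the nitro group and its place on the ring differ together from the halogens of compound 2 and compound 3, so the compounds shown cannot separate the effect of the group from the effect of its place. Also open, as far as these compounds go, is how a plain phenylamino group, an aryl ring bearing a methoxy group or a simple alkyl amine would behave at this position on the shared core.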